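A few compounds are considered here, and "the series" means these few. Any claim that something is new, unique, unknown or untested is made for them only; others in the source may bear on it.

Kinetic solubility across the series. In a physicochemical assay for solubility, read by nephelometry, in phosphate buffer, measured as kinetic solubility, at pH 6.5 (a lower number here means a less soluble compound, a higher number a more soluble compound), compound 1 `COc1ccc(-c2cc(-c3cccc(S(C)(=O)=O)c3)cnc2N)cn1` gives 25 ug/mL. Compound 2 `COc1ccc(-c2cc(-c3ccc(S(=O)(=O)NC4CC4)cc3)cnc2N)cn1` gives 6.3 ug/mL in this assay, and compound 3 `COc1ccc(-c2cc(-c3ccc(S(C)(=O)=O)c(F)c3)cnc2N)cn1` gives 6.3 ug/mL in this assay. Compound 2 and compound 3 are level at the digits shown, and the gap between them sits within the usual scatter. Against compound 1, compound 2 has the lower number, and that gap lies beyond the scatter, so compound 1 is the only member of the three whose solubility is clearly set apart.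

The next compound, compound 4 `COc1ccc(-c2cc(-c3ccc(-n4cncn4)cc3)cnc2N)cn1`, differs from compound 2 in one place: 1H-1,2,4-triazol-1-yl in place of cyclopropylsulfamoyl on an aromatic carbon. Within the data shown here, no measured pair in the set shows this change, so its effect on this assay is not known from the data. With a donor lost and a second aromatic ring gained, the expectation is a step from compound 2 to compound 4 of a 1.6-fold higher number from compound 2 to compound 4 (0.20 log units; within the scatter) in this assay, small and possibly no larger than the scatter. Compound 4 is therefore estimated at 10 ug/mL, with a range from 3 ug/mL to 30 ug/mL.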

Compound 4, solubility: 6.3 ug/mL
Compound 4: middle estimate off by 1.6-fold (0.20 log units), on the high side; measured number inside the range.
By their numbers in this assay, from the lowest: compounds 2, 3 and 4 (each within the scatter of the next); then compound 1.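

Among these compounds, this is the first step that can be read at a single place: on an aromatic carbon, para to a large group, 1H-1,2,4-triazol-1-yl in place of cyclopropylsulfamoyl gives no change at the digits printed from compound 2 to compound 4 (within the scatter) in this assay. The two groups differ in ring type and in counts, a five-membered aromatic ring with 0 hydrogen-bond donors against a three-membered non-aromatic ring with 1, yet the printed number stays the same at this position. No measurement in hand bears on why the number holds here.

On these data alone, both groups carry no net charge, so it remains open whether an amine or a carboxylic acid at this place would give a step beyond the scatter. This single step also leaves open whether the same swap would read the same way elsewhere on the molecule.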